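This account rests on a few compounds, and the source may have more. Where it says the series, first, only, none or still open, it means among the compounds named here.

Of the compounds shown here, three sharing one core have been tested in a functional assay on CCRF-CEM cells (Homo sapiens) for inhibition, read by sulforhodamine B assay, with a stated time of 48 h, tested at 10 uM; on this read-out higher numbers stand for more inhibition at the one concentration tested (going by the name of the read-out) and lower numbers for less inhibition. Compound 1 `COc1ccc(-c2cn3ccnc3c(-c3ccc4ncn(C5CCCCC5)c4c3)n2)cc1` gives 93.3% in this assay. Compound 2 `c1cn2cc(-c3ccsc3)nc(-c3ccc4ncn(C5CCCCC5)c4c3)c2n1` gives 29.2%. Compound 3 `CC(=O)c1ccc(-c2cn3ccnc3c(-c3ccc4ncn(C5CCCCC5)c4c3)n2)cc1` gives 1.1%, the lowest of the three numbers: its nearest neighbour is compound 2, and compound 1 lies furthest from it.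

Two measured steps involve compound 3. From compound 1 to compound 3, exchanging methoxy for acetyl on the pendant phenyl, inhibition fell by a number 92.2 percentage points lower from compound 1 to compound 3 (beyond the scatter). From compound 2 to compound 3, replacing thiophen-3-yl with 4-acetylphenyl, it fell by a number 28.1 percentage points lower from compound 2 to compound 3 (beyond the scatter).

Compound 4 `COc1ccccc1-c1cn2ccnc2c(-c2ccc3ncn(C4CCCCC4)c3c2)n1` has not yet been measured. It differs from compound 3 in one place: 2-methoxyphenyl in place of 4-acetylphenyl on an aromatic carbon. This largely reverses the change seen between compound 1 and compound 3, since a methoxyphenyl group returns, though the methoxy now sits at a different position of that phenyl ring. Because the step of a number 92.2 percentage points lower from compound 1 to compound 3 (beyond the scatter) was so large, a sizeable rise is expected for compound 4, with the shifted methoxy position adding uncertainty.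

The expected step is a number 63.9 percentage points higher from compound 3 to compound 4 (beyond the scatter), so compound 4 is estimated at 65%, within a range from 25% to 95%.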

Compound 4, a percentage reported as inhibition, at one concentration (the size of the read-out at that concentration, not a potency): 17.4%
Compound 4: middle estimate off by 47.6 percentage points, on the high side; the measured number lies below the stated range.
By their numbers in this assay, from the lowest: compound 3; then compound 4; then compound 2; then compound 1.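

In this assay, having a methoxy group on the phenyl ring is not enough, since where it sits matters: 2-methoxyphenyl in place of 4-methoxyphenyl gives a number 75.9 percentage points lower from compound 1 to compound 4 (beyond the scatter) and loses most of the inhibition. The same change keeps little advantage over the acetyl compound, with a number 16.3 percentage points higher from compound 3 to compound 4 (beyond the scatter) as a modest rise, and it stands slightly under the thiophene compound, with a number 11.8 percentage points lower from compound 2 to compound 4 (beyond the scatter) as a modest drop, so three different groups at this position all give low numbers and only 4-methoxyphenyl gives a high one. Nothing measured here explains why moving the methoxy group has so large an effect.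

From the compounds shown here alone, what stays open is whether the high number depends on the methoxy group itself or on any small group at that end of the ring, which 4-ethoxyphenyl, 4-hydroxyphenyl or 4-aminophenyl would test. Going by these compounds, it is also open how 3-methoxyphenyl or plain unsubstituted phenyl would compare, and whether the gaps seen at this one concentration would hold across a range of concentrations.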